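This account rests on a few compounds, and the source may have more. Where it says the series, first, only, none or still open, it means among the compounds named here.

Compound 1, `C[C@@H](Nc1c(C(=O)NCc2ccc(F)cc2)nc(Br)c2cccnc12)c1ccccc1`, stands at the edge of what a functional assay on HCT-116 cells (Homo sapiens) for cytotoxicity, read by MTT assay, with a stated time of 72 h (a lower number here means a stronger inhibitor, a higher number a weaker inhibitor), can report: in this assay compound 1 gives > 20000 nM, which is a limit of the assay rather than a number. Compound 2, `NCCCNc1c(C(=O)NCc2ccc(F)cc2)nc(Br)c2cccnc12`, gives > 20000 nM in this assay, again a limit. Compound 3, `CC(C)(C)OC(=O)N1CCN(c2c(C(=O)NCc3ccc(F)cc3)nc(Br)c3cccnc23)CC1`, gives > 10000 nM in this assay, also a limit. Going by the values given here, the only measured step touching compound 1, a step that the two limits leave unreadable from compound 1 to compound 2, cannot be sized. Compound 4, `N[C@H]1CC[C@H](Nc2c(C(=O)NCc3ccc(F)cc3)nc(Br)c3cccnc23)CC1`, differs from compound 1 by 4-aminocyclohexyl in place of 1-phenylethyl on a nitrogen on an aromatic ring. With every value shown resting at a limit (the limit of > 10000 nM in this assay, at which 1 of the 3 values shown sits, and (the limit of > 20000 nM in this assay, at which 2 of the 3 values shown sit)), no direction or size of change can be read from the measured compounds. Compound 4 is therefore expected to sit near the limit as well, estimated at 25000 nM with a range from 8000 nM to 80000 nM. This amounts to an expected step that the limit leaves unreadable from compound 1 to compound 4.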

Compound 4, half-maximal inhibitory concentration: 7000 nM
Compound 4: middle estimate off by 3.6-fold (0.55 log units), on the high side; measured number outside the range, below it.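

On this nitrogen, 4-aminocyclohexyl is the first group shown to give a number rather than a limit in this assay, with an at least 2.8-fold lower number from compound 1 to compound 4 (0.45 log units; beyond the scatter) and an at least 2.8-fold lower number from compound 2 to compound 4 (0.45 log units; beyond the scatter). Compound 2, whose 3-aminopropyl also carries an amino group, gives > 20000 nM, which is a limit. Both steps are only minimum sizes because compounds 1 and 2 rest at a limit: the limit of > 20000 nM in this assay, at which 2 of the 4 values shown sit.

The compounds shown leave open whether the cyclohexyl ring or its amino group accounts for the value of compound 4, 7000 nM. Plain cyclohexyl or 4-hydroxycyclohexyl on this nitrogen would separate the two.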